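Iodo for ethynyl, repeated on the second core

The compounds below may be only part of what the source reports. "The series", "measured", "known", "first", "only" and "open" are said of these compounds alone.

Compound 2 `C#Cc1cn([C@@H]2O[C@H](CO)[C@@H](O)[C@H]2O)c2ncnc(C)c12` is the reference point; in a functional assay on HepG2 cells (Homo sapiens) for antiproliferative activity, read by XTT assay, with a stated time of 72 h (on this read-out lower numbers stand for stronger inhibition and higher numbers for weaker inhibition), compound 2 gives 290 nM. Compound 1 `Cc1ncnc2c1c(I)cn2[C@@H]1O[C@H](CO)[C@@H](O)[C@H]1O` carries the change (iodo in place of ethynyl on an aromatic carbon), and in this assay compound 1 gives 3460 nM, a step of a 12-fold higher number from compound 2 to compound 1 (1.08 log units; beyond the scatter). Compound 3 `C#Cc1cn([C@@H]2O[C@H](CO)[C@@H](O)[C@H]2O)c2ncnc(NC)c12` differs from compound 2 in the core by methylamino in place of methyl on an aromatic carbon. In this assay compound 3 gives only a limit of the assay, > 15000 nM. The resulting step, an at least 51-fold higher number from compound 2 to compound 3 (1.71 log units; beyond the scatter), is bounded by the limit of > 15000 nM in this assay, at which 1 of the 3 values shown sits. Compound 4 `CNc1ncnc2c1c(I)cn2[C@@H]1O[C@H](CO)[C@@H](O)[C@H]1O` is not yet measured; it differs from compound 3 by iodo in place of ethynyl on an aromatic carbon, which is the same change as from compound 2 to compound 1, here made on the core of compound 3 rather than on the core of compound 2. The earlier step, a 12-fold higher number from compound 2 to compound 1 (1.08 log units; beyond the scatter), raised the number, and the same direction is expected on the second core. The step from compound 3 is therefore estimated at a step that the limit leaves unreadable from compound 3 to compound 4, counted from a starting point that is itself only a limit. Compound 4 is expected to give 60000 nM in this assay, most probably reported again only as a limit.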

Compound 4, half-maximal inhibitory concentration: > 20000 nM
Compound 4 ended at the assay's limit; the forecaster's own chance of this, stated with the estimate: 90%; the middle value lies beyond the limit too.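

In this assay compound 4 gives > 20000 nM, which is a limit of the assay, and the step for iodo in place of ethynyl on the core of compound 3 cannot be read, as that core's starting point is also only a limit. The methylamino in place of methyl change can still be followed on both cores, where the new step is an at least 5.7-fold higher number from compound 1 to compound 4 (0.76 log units; beyond the scatter) and the direction matches the earlier one: the same change on two cores in this assay, an at least 51-fold higher number (1.71 log units; beyond the scatter) from compound 2 to compound 3 and an at least 5.7-fold higher number (0.76 log units; beyond the scatter) from compound 1 to compound 4; the limit leaves it open whether they differ Thus the direction of the methylamino change carries from the ethynyl compounds to the iodo compounds, but the data do not show whether its size carries over, or whether the rise seen in a 12-fold higher number from compound 2 to compound 1 (1.08 log units; beyond the scatter) recurs on the core of compound 3.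

On these data alone, it remains open how this assay responds when a plain amine, a hydrogen or a longer chain stands where methyl and methylamino sit. Also open, as far as these compounds go, is whether a nitrile or a bromo group in place of ethynyl or iodo would follow the same order on the core of compound 2.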